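The source may hold more compounds than are shown below. What is called first, only, known or untested is meant among the compounds shown, and "the series" means these compounds.

Measured in a functional assay on MCF7 cells (Homo sapiens) for inhibition, read by MTT assay, with a stated time of 4 days; a lower number here means a stronger inhibitor, a higher number a weaker inhibitor:
- compound 1, `COc1cc(NC(C)CCCNC(=O)NNC(=O)N(CCO)CCO)c2ncccc2c1`: 29000 nM
- compound 2, `COc1cc(NC(C)CCCNC(=O)NNC(=O)Nc2ccc(Cl)c(C(F)(F)F)c2)c2ncccc2c1`: 2000 nM
- compound 3, `COc1cc(NC(C)CCCNC(=O)NNC(=O)NCCCO)c2ncccc2c1`: 13000 nM

Compound 3 holds the second highest of the three numbers: it sits nearest to compound 1, with a 2.2-fold lower number from compound 1 to compound 3 (0.35 log units; beyond the scatter), and furthest from compound 2, with a 6.5-fold higher number from compound 2 to compound 3 (0.81 log units; beyond the scatter). Compound 4, `COc1cc(NC(C)CCCNC(=O)NNC(=O)NC(CO)(CO)CO)c2ncccc2c1`, differs from compound 3 only at one spot: 2-hydroxy-1,1-bis(hydroxymethyl)ethyl in place of 3-hydroxypropyl on an amide-type nitrogen. The step that bears on this is a 2.2-fold lower number from compound 1 to compound 3 (0.35 log units; beyond the scatter), where one hydroxyl-bearing group replaced another and the number moved modestly; the larger step of a 6.5-fold higher number from compound 2 to compound 3 (0.81 log units; beyond the scatter) involved an aryl group and is less comparable. A modest rise in this assay is therefore expected for compound 4, as a 1.9-fold higher number from compound 3 to compound 4 (0.28 log units; within the scatter). Compound 4 is estimated at 25000 nM, with a range from 10000 nM to 60000 nM.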

Compound 4, half-maximal inhibitory concentration: 28000 nM
Estimate against measurement, compound 4: 1.1-fold (0.05 log units) below; low and high end bracket the measured number.
By their numbers in this assay, from the lowest: compound 2; then compound 3; then compounds 4 and 1 (each within the scatter of the next).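

In this assay, putting 2-hydroxy-1,1-bis(hydroxymethyl)ethyl in place of 3-hydroxypropyl on this amide-type nitrogen gives a 2.2-fold higher number from compound 3 to compound 4 (0.33 log units; beyond the scatter), so here the group with more hydroxyl groups goes with the weaker number. The gap to the aryl group of compound 2 grows to a 14-fold higher number from compound 2 to compound 4 (1.15 log units; beyond the scatter), while the different hydroxyl-bearing end groups of compound 1 and compound 4 cannot be told apart (a 1.0-fold lower number from compound 1 to compound 4 (0.02 log units; within the scatter)). Nothing measured here gives a reason for these differences. Still open, as far as these compounds go, is how an amine, a carboxylic acid or a longer hydroxyalkyl chain on this nitrogen would read in this assay. Also open, from the compounds shown here alone, is whether a phenyl ring without the chlorine or the trifluoromethyl would keep the low number of compound 2.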